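Methyl removal in thiosemicarbazide series: compound 3 to compound 4

The source may report more compounds than this note shows. Statements on the series, on what has been measured and on what is new or still open speak of the compounds shown alone.

Measured compounds:
compound 1 `N/C(=N\NC(=S)N1CCOCC1)c1ccccn1` 26.8%
compound 2 `Cc1cccc(/C(N)=N/NC(=S)N2CCSCC2)n1` 47.2%
compound 3 `Cc1ccnc(/C(N)=N/NC(=S)N2CCSCC2)c1` 47.7%

Of the compounds shown here, three have been tested in a functional assay on A-375 cells (Homo sapiens) for cytotoxicity, read by MTT assay, with a stated time of 72 h, tested at 1 uM; a lower number here means less inhibition of growth, a higher number more inhibition of growth at the concentration tested. Compound 3 gives 47.7%, the highest of the three numbers. Its nearest neighbour is compound 2, whose value of 47.2% lies within the scatter of the reading for compound 3, so no order between them can be claimed. Compound 1, with 26.8%, stands furthest away, and that gap lies beyond the scatter.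

Compound 4 `N/C(=N\NC(=S)N1CCSCC1)c1ccccn1` has not yet been measured in this assay. It differs from compound 3 in one place: hydrogen in place of methyl on an aromatic carbon. Among the compounds with values here, no step between two measured compounds isolates this change, so the expectation rests on the series as a whole. Compounds 2 and 3 carry methyl in different positions and give near-identical numbers, which suggests the methyl contributes little. Compound 4 is therefore expected to show a step from a number 6.7 percentage points lower from compound 3 to compound 4 (within the scatter), small and, if anything, downward, probably within the scatter. Compound 4 is estimated at 41%, with a range from 26% to 55%.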

Compound 4, percent growth inhibition at one concentration: 34%
Compound 4: middle estimate off by 7 percentage points, on the high side; measured number inside the range.
By their numbers in this assay, from the lowest: compounds 1 and 4 (each within the scatter of the next); then compounds 2 and 3 (each within the scatter of the next).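

In this assay, the methyl on the aromatic carbon opposite the ring nitrogen proves to count: hydrogen in its place gives a number 13.7 percentage points lower from compound 3 to compound 4 (beyond the scatter), and the same exchange read from the other methyl-bearing compound gives a number 13.2 percentage points lower from compound 2 to compound 4 (beyond the scatter). The change at the other end of the molecule, thiomorpholin-4-yl in place of morpholin-4-yl, can now be read as well and gives a number 7.2 percentage points higher from compound 1 to compound 4 (within the scatter), so in the compounds without methyl this exchange shows no difference beyond the scatter. No measurement at hand accounts for the loss that comes with removing the methyl.

As far as these compounds go, it remains open whether an ethyl, a methoxy group or an amine on the same aromatic carbon would match the methyl or exceed it. Also open, from the compounds shown here alone, is whether morpholin-4-yl and thiomorpholin-4-yl would stay equally close with a methyl present.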